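Swapping Methyl for Chloro on the Aromatic Ring

A few compounds are considered here, and "the series" means these few. Any claim that something is new, unique, unknown or untested is made for them only; others in the source may bear on it.

In a functional assay on PC-3 cells (Mus musculus) for cytotoxicity against PC-3 (Homo sapiens) (a lower number here means a stronger inhibitor, a higher number a weaker inhibitor), compound 1 (`CCCN(CCC)c1c([N+](=O)[O-])cc(S(=O)(=O)Nc2ccc(OC)cc2)cc1[N+](=O)[O-]`) gives 31000 nM. Compound 2 (`CCCN(CCC)c1c([N+](=O)[O-])cc(S(=O)(=O)Nc2ccc(C)cc2)cc1[N+](=O)[O-]`) gives 21000 nM, so it stands within the scatter of compound 1. Compound 3 (`CCCN(CCC)c1c([N+](=O)[O-])cc(S(=O)(=O)Nc2ccc(Cl)cc2)cc1[N+](=O)[O-]`) brings one change, chloro in place of methyl on an aromatic carbon. For the measured compounds named here, only one measured step bears on this spot, a 1.5-fold lower number from compound 1 to compound 2 (0.17 log units; within the scatter), and it is small. No shift beyond the scatter is therefore expected in this assay, and the expected move is a 1.1-fold lower number from compound 2 to compound 3 (0.02 log units; within the scatter). For compound 3 the estimated value is 20000 nM, within an expected range of 10000 nM to 40000 nM.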

Compound 3, half-maximal inhibitory concentration: 16000 nM
Compound 3: middle estimate off by 1.3-fold (0.10 log units), on the high side; the range from low to high includes it.
By their numbers in this assay, from the lowest: compounds 3, 2 and 1 (each within the scatter of the next).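

In this assay, chloro in place of methyl gives a 1.3-fold lower number from compound 2 to compound 3 (0.12 log units; within the scatter), and chloro in place of methoxy gives a 1.9-fold lower number from compound 1 to compound 3 (0.29 log units; within the scatter). Both steps lie within the scatter, so methoxy, methyl and chloro on this aromatic carbon, para to a large group, cannot be told apart in this assay. Nothing available explains this insensitivity. As far as these compounds go, whether an amine or a carboxylic acid on the same carbon would give a step beyond the scatter remains open. So does the outcome for a longer chain there.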